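Cyclopropenyl-methylidene purines: tolerance on a lymphoblast line

The source may report more compounds than this note shows. Statements on the series, on what has been measured and on what is new or still open speak of the compounds shown alone.

Measured so far:
compound 1 `Nc1nc(NC2CCCCC2)c2ncn(/C=C3/CC3(CO)CO)c2n1` — > 20000 nM, a limit
compound 2 `CC(C)CNc1nc(N)nc2c1ncn2/C=C1/CC1(CO)CO` — > 20000 nM, a limit
compound 3 `Nc1nc(OCC(F)(F)F)c2ncn(/C=C3/CC3(CO)CO)c2n1` — > 20000 nM, a limit

In an ADME assay on CCRF-HSB-2 cells (Homo sapiens) for cytotoxicity, with a stated time of 7 days (a higher number here means that more compound is tolerated, a lower number that less compound is tolerated), compound 1 reaches only the limit of > 20000 nM. In this assay compound 2 likewise stops at the limit of > 20000 nM. For compound 3 this assay again gives only the limit of > 20000 nM. Thus every number so far is a limit and no compound can be placed relative to another: the limit of > 20000 nM in this assay, at which 3 of the 3 values shown sit. The steps a step that the two limits leave unreadable from compound 1 to compound 2, a step that the two limits leave unreadable from compound 1 to compound 3 and a step that the two limits leave unreadable from compound 2 to compound 3 are therefore all unreadable in size, whether the change is isobutyl in place of cyclohexyl on a nitrogen on an aromatic ring or 2,2,2-trifluoroethoxy in place of an alkylamino group on an aromatic carbon.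

Compound 4 `COCCOc1nc(N)nc2c1ncn2/C=C1/CC1(CO)CO` is the next member to be measured. It differs from compound 2 as follows: 2-methoxyethoxy in place of isobutylamino on an aromatic carbon. The step from compound 2 to compound 3 is the nearest measured comparison, an aromatic-carbon exchange of an alkylamino group for an ether, and it sits at the limit on both ends. Within the data shown here, no measured step bears a readable size on this exchange. The expectation for compound 4 is therefore that this assay again reports only the limit, with an expected step that the limit leaves unreadable from compound 2 to compound 4 of no readable size, and an estimated value of 30000 nM within 10000 nM to 100000 nM.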

Compound 4, half-maximal cytotoxic concentration: > 20000 nM
Compound 4: only a limit was reported (the forecaster's own chance of this, stated with the estimate: 85%); the middle value does not contradict the limit.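

In this assay compound 4 gives > 20000 nM, again only a limit. Its steps to compound 1, compound 2 and compound 3 therefore cannot be read. Left open is the concentration at which any of these compounds becomes cytotoxic, and so whether the amino and ether groups differ at all.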